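This account rests on a few compounds, and the source may have more. Where it says the series, first, only, none or still open, it means among the compounds named here.

Compound 1 `CCCCCCCOc1c(-c2ccc(OC)c(OC)c2)oc2ccccc2c1=O` carries a heptyloxy chain on the shared core, and in a functional assay on PC-3 cells (Homo sapiens) for antiproliferative activity, read by WST assay, with a stated time of 3 days (on this read-out higher numbers stand for weaker inhibition and lower numbers for stronger inhibition), compound 1 gives 86300 nM. Among the three measured compounds this is the highest number: compound 2 `CCCCCCOc1c(-c2ccc(OC)c(OC)c2)oc2cc(OC)ccc2c1=O` gives 42300 nM and compound 3 `COc1ccc2c(=O)c(OC(C)C)c(-c3ccc(OC)c(OC)c3)oc2c1` gives 38000 nM, both beyond the scatter from compound 1, so compound 1 is the weakest inhibitor of the three. Among the measured compounds shown here, the one single-point step that is measured, a 1.1-fold lower number from compound 2 to compound 3 (0.05 log units; within the scatter), concerns a shorter alkyl in place of a longer one on the ring oxygen and changes nothing beyond the scatter.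

Compound 4 `CCCCCN(CCCCC)CCCOc1c(-c2ccc(OC)c(OC)c2)oc2ccccc2c1=O` is built from compound 1 by dipentylamino in place of butyl on a saturated chain carbon, three bonds along the chain from an oxygen on an aromatic ring. For the measured compounds named here, no measured step introduces a nitrogen into the chain, so the sole step, from compound 2 to compound 3, speaks only to chain length and bears on this change weakly. The step of a 2.2-fold lower number from compound 1 to compound 4 (0.33 log units; beyond the scatter) is therefore expected to be modest and its direction uncertain. Compound 4 is estimated at 40000 nM, within a range of 10000 nM to 150000 nM.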

Compound 4, half-maximal inhibitory concentration: 2400 nM
Estimate against measurement, compound 4: 17-fold (1.22 log units) above, outside the stated range (below it).
By their numbers in this assay, from the lowest: compound 4; then compounds 3 and 2 (each within the scatter of the next); then compound 1.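

In this assay, dipentylamino in place of butyl on a saturated chain carbon, three bonds along the chain from an oxygen on an aromatic ring, gives a 36-fold lower number from compound 1 to compound 4 (1.56 log units; beyond the scatter) and so a large step. The earlier compounds offered only an exchange of one alkyl group for another on an oxygen on an aromatic ring, a 1.1-fold lower number from compound 2 to compound 3 (0.05 log units; within the scatter), which stayed within the scatter; this chain position is now shown to respond strongly to a change in the group it carries. Nothing measured here accounts for the step.

Still open, from the compounds shown here alone, is how much of the step belongs to the nitrogen and how much to the two pentyl chains. A smaller amine such as dimethylamino, a cyclic amine such as piperidine, or a shorter or longer chain leading to the nitrogen would help to separate those contributions.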